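This account rests on a few compounds, and the source may have more. Where it says the series, first, only, none or still open, it means among the compounds named here.

Working notes on the series sharing the core of compound 1 (`COc1ccc(NC(=O)C2CCCNC2)cc1`), followed in a functional assay on a cell-free system (Platelet, plasma, Homo sapiens) for inhibition; a higher number here means a weaker inhibitor, a lower number a stronger inhibitor. Compound 1 stands at "not determined" (no result reported) (no number), and compound 3 (`CCCCCCOc1cccc(NC(=O)C2CCCNC2)c1`) stands at "not determined" (no result reported) (again no number). Within the data shown here, compound 2 (`CCCCCCOc1ccc(NC(=O)C2CCCNC2)cc1`) gives 43000 nM as the only number so far, so it has no rank. Compound 4 (`O=C(Nc1ccc(OCc2ccc(F)cc2)cc1)C1CCCNC1`) differs from compound 2 by one change: 4-fluorophenyl in place of pentyl on a saturated chain carbon bound to an oxygen on an aromatic ring. Among the measured compounds shown here, no measured step exists to calibrate this change, so only a modest move toward stronger inhibition is expected. The estimated step is a 2.2-fold lower number from compound 2 to compound 4 (0.33 log units; beyond the scatter) (direction uncertain). Compound 4 is estimated at 20000 nM (expected range 5000 nM to 80000 nM).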

Compound 4, half-maximal inhibitory concentration: 90000 nM
Estimate against measurement, compound 4: 4.5-fold (0.65 log units) below; the whole stated range lies below it.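

In this assay, among these compounds, 4-fluorophenyl in place of pentyl on a saturated chain carbon bound to an oxygen on an aromatic ring gives a 2.1-fold higher number from compound 2 to compound 4 (0.32 log units; beyond the scatter), the first readable step. At this place, the aromatic ring keeps a measurable number but gives weaker inhibition than the chain of compound 2. No measured evidence bears on the cause of this step. Still open, from the compounds shown here alone, is whether plain phenyl, a longer chain, an amine or a carboxylic acid at this place would move the number, and in which direction.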